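Sulfonyl substituent trimmed in an acid-bearing alkyne series

The source may report more compounds than this note shows. Statements on the series, on what has been measured and on what is new or still open speak of the compounds shown alone.

Among the compounds with values here, compound 1 `COCCN(C)S(=O)(=O)c1ccc(C)c(C#Cc2cc(Cl)ccc2OCC(=O)O)c1` is the only member of the set with a number: in an ADME assay on a cell-free system (plasma, Homo sapiens) (a higher number here means a larger unbound share of the compound, a lower number a smaller unbound share), compound 1 gives 0.006. Compound 2 `Cc1ccc(S(=O)(=O)CC(C)C)cc1C#Cc1cc(Cl)ccc1OCC(=O)O` belongs to the same series, but in this assay compound 2 gives "not determined" (no result reported), so it adds no reference point. Within the data shown here, compound 1 therefore stands alone, and there is no measured step to set the size of a substituent change against.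

Compound 3 `Cc1ccc(S(C)(=O)=O)cc1C#Cc1cc(Cl)ccc1OCC(=O)O` has not been measured in this assay. Relative to compound 1 it carries methyl in place of (2-methoxyethyl)(methyl)amino on a sulfonyl sulfur. Among the measured compounds shown here, with no measured step for comparison, the expected change in this assay is a modest rise in unbound fraction, a step of a 2.0-fold higher number from compound 1 to compound 3 (0.30 log units; within the scatter) that is expected to sit near the edge of the usual scatter rather than clearly beyond it. On that basis compound 3 is estimated to give 0.012 in this assay, with a range from 0.004 to 0.04.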

Compound 3, unbound fraction: 0.017
Beside the measured number, compound 3's estimate is 1.4-fold (0.15 log units) below it; low and high end bracket the measured number.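

In this assay, within the data shown here, methyl in place of (2-methoxyethyl)(methyl)amino on a sulfonyl sulfur gives a 2.8-fold higher number from compound 1 to compound 3 (0.45 log units; beyond the scatter), the only measured step in the set. The substituent on the sulfonyl sulfur therefore registers in this read-out: going from six heavy atoms to one, with the loss of the nitrogen and the hydrogen-bond acceptor counted in the leaving group, moves the unbound fraction beyond the scatter, although the step remains modest. Nothing measured here accounts for the size or direction of this step.

This single step cannot separate the removal of the amino nitrogen from the shortening of the substituent, as the two changes travel together. As far as these compounds go, it remains open whether a dimethylamino group on the sulfonyl sulfur would read closer to compound 1 or compound 3, and how a longer chain ending in a hydroxyl or an amine would read.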